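Working notes: nitro in place of methoxy, compound 4

The source may report more compounds than this note shows. Statements on the series, on what has been measured and on what is new or still open speak of the compounds shown alone.

Measured in a functional assay on MDA-MB-231 cells (Homo sapiens) for antiproliferative activity, read by MTT assay, with a stated time of 72 h (a lower number here means a stronger inhibitor, a higher number a weaker inhibitor), so far:
- compound 1 `COc1ccc(-n2ccnc2-c2cc(OC)c(OC)c(OC)c2)cc1[N+](=O)[O-]` gives 7500 nM
- compound 2 `COc1cc(-c2nccn2-c2cccc(C)c2)cc(OC)c1OC` gives 11700 nM
- compound 3 `COc1cccc(-n2ccnc2-c2cc(OC)c(OC)c(OC)c2)c1` gives 18300 nM

Compound 3 sits within the scatter of compound 2 and at a higher number than compound 1. Unmeasured compound 4 `COc1cc(-c2nccn2-c2cccc([N+](=O)[O-])c2)cc(OC)c1OC` has nitro in place of methoxy on an aromatic carbon, meta to a large group (nitro in place of methoxy on an aromatic carbon). Among the compounds with values here, the one measured step at this place is methyl to methoxy, a 1.6-fold higher number from compound 2 to compound 3 (0.19 log units; within the scatter), which stays within the scatter. Within the data shown here, no measured step covers nitro directly. Compound 1 at 7500 nM also bears a nitro, alongside a further methoxy, so a modest move to a lower number is expected. The expected step is a 1.8-fold lower number from compound 3 to compound 4 (0.26 log units; within the scatter) in this assay as estimated here. For compound 4 the estimate is 10000 nM (expected range 4500 nM to 22000 nM).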

Compound 4, half-maximal inhibitory concentration: > 100000 nM
Compound 4: a limit, no number (the forecaster's own chance of this, stated with the estimate: 5%); middle value at least 10-fold (1.00 log units) away from the limit.
By their numbers in this assay, from the lowest: compounds 1, 2 and 3 (each within the scatter of the next, the first and the last beyond it). At a limit, above all of these: compound 4.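

In this assay compound 4 stands at a limit, not a number: the limit of > 100000 nM in this assay, at which 1 of the 4 values shown sits.

At this position, nitro in place of methoxy gives an at least 5.4-fold higher number from compound 3 to compound 4 (0.73 log units; beyond the scatter) and nitro in place of methyl gives an at least 8.5-fold higher number from compound 2 to compound 4 (0.93 log units; beyond the scatter), whereas methoxy in place of methyl stayed within the scatter, so this position does not tolerate every small group alike. Hydrogen in place of the further methoxy of compound 1 gives an at least 13-fold higher number from compound 1 to compound 4 (1.12 log units; beyond the scatter), so a nitro on this ring keeps a measurable value only with that methoxy present.

From the compounds shown here alone, how far compound 4 lies beyond its limit remains unknown. Going by these compounds, whether an amine or a carboxylic acid at this position gives a measurable value also remains open.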